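The compounds below may be only part of what the source reports. "The series", "measured", "known", "first", "only" and "open" are said of these compounds alone.

Measured so far in a functional assay on C8166 cells (Homo sapiens) for cytotoxicity, read by MTT assay (on this read-out lower numbers stand for higher toxicity in this test and higher numbers for lower toxicity in this test), are two compounds
compound 1 `Cc1cccc(C(=O)Nc2cc(Cl)ccc2OCC(=O)Nc2ccc(S(N)(=O)=O)cc2C)c1` with 52900 nM
compound 2 `Cc1ccc(C(=O)Nc2cc(Cl)ccc2OCC(=O)Nc2ccc(S(N)(=O)=O)cc2C)cc1C` with 84100 nM

Going by the values given here, on these numbers compound 2 stands at 84100 nM and lies within the scatter of compound 1 at 52900 nM in this assay as its only neighbour. The next compound to be tested is compound 3 `Cc1cc(C)cc(C(=O)Nc2cc(Cl)ccc2OCC(=O)Nc2ccc(S(N)(=O)=O)cc2C)c1` which has the same atoms as compound 2, joined differently. The difference is 3,5-dimethylphenyl in place of 3,4-dimethylphenyl on a carbonyl carbon and the rest of the structure stays the same, with 3,5-dimethylphenyl in place of 3,4-dimethylphenyl on a carbonyl carbon.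

Among the compounds with values here, only one measured step bears on this change, and it bears only loosely. It is a 1.6-fold higher number from compound 1 to compound 2 (0.20 log units; within the scatter) for methyl in place of hydrogen on an aromatic carbon. Within the data shown here, that step adds a methyl group, whereas the present change adds no atom, and no measured pair shows a methyl group changing place. With so little to go on, no shift beyond the scatter is expected. The expected step is a 1.2-fold lower number from compound 2 to compound 3 (0.09 log units; within the scatter) and it rests on this single comparison. For compound 3 the estimated value is 68000 nM with an expected range from 32000 nM to 140000 nM in this test.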

Compound 3, half-maximal cytotoxic concentration: 36500 nM
The estimate for compound 3 lay 1.9-fold (0.27 log units) above the measured number; the measured number falls inside the stated range.
By their numbers in this assay, from the lowest: compounds 3, 1 and 2 (each within the scatter of the next, the first and the last beyond it).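

In this assay, going by these compounds alone, the arrangement of the two methyl groups matters more than the earlier compounds could show: 3,5-dimethylphenyl in place of 3,4-dimethylphenyl on the carbonyl carbon gives a 2.3-fold lower number from compound 2 to compound 3 (0.36 log units; beyond the scatter), which points to modestly higher toxicity in this test for the same atoms joined differently. Each route that adds a methyl group to compound 1 stays within the scatter, with a 1.6-fold higher number from compound 1 to compound 2 (0.20 log units; within the scatter) on one side and a 1.4-fold lower number from compound 1 to compound 3 (0.16 log units; within the scatter) on the other. The two dimethylphenyl compounds thus lie on either side of compound 1 and are separated from each other only by a step that is beyond the scatter, though not by much. Nothing available explains why moving a methyl group should shift this read-out.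

On these data alone, what a methoxy group or a chlorine atom in place of one of these methyl groups would do to the number remains open. As far as these compounds go, it is equally open whether a longer chain such as ethyl would follow compound 2 or compound 3, and whether the step between these two arrangements would hold on another core.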